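This account rests on a few compounds, and the source may have more. Where it says the series, first, only, none or still open, it means among the compounds named here.

Measured so far in a functional assay on the whole organism with Rattus norvegicus as the target, read by paw edema, at a dose of 50 mg/kg by the oral route; on this read-out lower numbers stand for less inhibition and higher numbers for more inhibition at the one dose given (going by the name of the read-out):

compound 1, `Cc1ccc(-c2nn3c(-c4cc(Cl)cc(Cl)c4Cl)nnc3s2)cc1`, 22.6%
compound 2, `Clc1cc(Cl)c(Cl)c(-c2nnc3sc(-c4ccncc4Br)nn23)c1`, 19.4%
compound 3, `COc1ccc(-c2nn3c(-c4cc(Cl)cc(Cl)c4Cl)nnc3s2)cc1`, 25.8%

Compound 3 has the highest of the three numbers, but its lead is small: against compound 1 the step is a number 3.2 percentage points higher from compound 1 to compound 3 (within the scatter), and against compound 2 it is a number 6.4 percentage points higher from compound 2 to compound 3 (within the scatter), both within the scatter. The three numbers are therefore level on this read-out within the scatter, and the inhibition in this assay for compound 3 cannot be called higher than that of compound 1 or compound 2.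

Compound 4, `Clc1cc(Cl)c(Cl)c(-c2nnc3sc(-c4ccncc4)nn23)c1`, has not been measured. It differs from compound 3 by pyridin-4-yl in place of 4-methoxyphenyl on an aromatic carbon.

Among the measured compounds shown here, two measured steps bear on this change. The step of a number 6.4 percentage points higher from compound 2 to compound 3 (within the scatter) runs the opposite way, exchanging a substituted pyridin-4-yl for the 4-methoxyphenyl, and stayed within the scatter. The step of a number 3.2 percentage points lower from compound 1 to compound 2 (within the scatter), which also introduces a pyridin-4-yl group in place of a para-substituted phenyl, likewise stayed within the scatter. For the measured compounds named here, no step has moved the read-out beyond the scatter, so for compound 4 a step of about a number 5.8 percentage points lower from compound 3 to compound 4 (within the scatter) is expected, not beyond the scatter, leaning slightly lower in line with compound 2 at 19.4%.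

Compound 4 is thus estimated at 20%, with a range from 10% to 31%.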

Compound 4, a percentage reported as inhibition, in the whole organism at one dose (the size of the read-out at that dose, not a potency): 11.3%
Compound 4: middle estimate off by 8.7 percentage points, on the high side, within the range that was stated.
By their numbers in this assay, from the lowest: compounds 4, 2, 1 and 3 (each within the scatter of the next, the first and the last beyond it).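

In this assay, this position on the five-membered aromatic ring with 2 nitrogen and 1 sulfur now shows steps beyond the scatter: pyridin-4-yl in place of 4-methoxyphenyl gives a number 14.5 percentage points lower from compound 3 to compound 4 (beyond the scatter), and pyridin-4-yl in place of 4-methylphenyl gives a number 11.3 percentage points lower from compound 1 to compound 4 (beyond the scatter), so the group here can matter for the read-out, though only modestly. Hydrogen in place of bromo on the pyridin-4-yl gives a number 8.1 percentage points lower from compound 2 to compound 4 (within the scatter), so compound 2 and compound 4 cannot be told apart, and the bromo group has no effect that can be claimed from this pair. No measurement shown here accounts for these steps.

On these data alone, whether pyridin-4-yl carrying an amine or a carboxylic acid would read like compound 4 or like compound 3 remains open, as does the result for a phenyl group with a hydroxyl or a longer alkoxy chain at this place. As far as these compounds go, all the numbers come from a single oral dose, so how these steps would look at other doses also remains open.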